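Branching a Chain on Two Different Cores

A few compounds are considered here, and "the series" means these few. Any claim that something is new, unique, unknown or untested is made for them only; others in the source may bear on it.

Measured so far:
- compound 1 `CC(C)c1ccccc1-c1ccc2[nH]ncc2c1`: 514 nM
- compound 2 `CC(C)(C)c1ccccc1-c1ccc2[nH]ncc2c1`: 3400 nM
- compound 3 `CCc1cc2[nH]ncc2cc1-c1ccccc1C(F)(F)F`: 50 nM

All three were tested in an assay on CHO-TREX cells for antagonist activity at transient receptor potential cation channel subfamily A member 1 (Homo sapiens), read by FLIPR and calcium flux, with a stated time of 10 min; a higher number here means a weaker inhibitor, a lower number a stronger inhibitor. Compound 2 differs from compound 1 by methyl in place of hydrogen on a saturated chain carbon bound to an aromatic carbon and two saturated chain carbons, and this gave a 6.6-fold higher number from compound 1 to compound 2 (0.82 log units; beyond the scatter). Compound 3 carries a trifluoromethyl group and an ethyl group on a core whose difference from the core of compound 1 is not broken down here; compound 3 has the lowest number of the three.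

Compound 4 `CC(C)c1cc2[nH]ncc2cc1-c1ccccc1C(F)(F)F`, not yet measured, differs from compound 3 by methyl in place of hydrogen on a saturated chain carbon bound to an aromatic carbon and a saturated chain carbon. This is the same kind of change as between compound 1 and compound 2, though here the place is a saturated chain carbon bound to an aromatic carbon and one saturated chain carbon rather than two. Because compound 2 showed a 6.6-fold higher number from compound 1 to compound 2 (0.82 log units; beyond the scatter), a weakening is expected for compound 4 as well, but smaller, so the expected step is a 2.6-fold higher number from compound 3 to compound 4 (0.41 log units; beyond the scatter). Compound 4 is estimated at 130 nM, between 45 nM and 400 nM.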

Compound 4, half-maximal inhibitory concentration: 25400 nM
Compound 4: middle estimate off by 200-fold (2.29 log units), on the low side; the measured number lies above the stated range.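

On the core of compound 3, putting methyl in place of hydrogen on a saturated chain carbon bound to an aromatic carbon and a saturated chain carbon gave a 510-fold higher number from compound 3 to compound 4 (2.71 log units; beyond the scatter) in this assay. The direction of the change carried from one core to the other, but its size did not: the same change on two cores in this assay, a 6.6-fold higher number (0.82 log units; beyond the scatter) from compound 1 to compound 2 and a 510-fold higher number (2.71 log units; beyond the scatter) from compound 3 to compound 4, 77-fold (1.89 log units) apart, beyond the scatter of two such steps. These two steps cannot separate the influence of the core from that of the carbon carrying the new methyl, which also differs between them, and they give no reason for the gap.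

On these data alone, it remains open how a longer chain, an amine or a carboxylic acid in place of ethyl would behave on the core of compound 3. As far as these compounds go, it also remains open whether the same methyl change on further cores would resemble either step.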